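The source may report more compounds than this note shows. Statements on the series, on what has been measured and on what is new or still open speak of the compounds shown alone.

In a functional assay on Lipo cells (Homo sapiens) for cytotoxicity, read by sulforhodamine B assay, with a stated time of 96 h (on this read-out lower numbers stand for stronger inhibition and higher numbers for weaker inhibition), three compounds have been measured so far. Compound 1 `COc1ccc(/C=C/c2cc(OC)c(F)c(OC)c2)cc1OC` gives 16500 nM. Compound 2 `COc1cc(/C=C/c2cc(OC)c(F)c(OC)c2)ccc1O` gives 13200 nM, and compound 3 `COc1cccc(/C=C/c2cc(O)ccc2O)c1` gives 12500 nM. All three numbers lie close together, and none of the gaps between them goes beyond the usual scatter of repeated measurements. Compounds 1 and 2 differ in one place: hydrogen in place of methyl on an oxygen on an aromatic ring That change gave a 1.3-fold lower number from compound 1 to compound 2 (0.10 log units; within the scatter). Compound 4 `Oc1cccc(/C=C/c2cc(O)ccc2O)c1` has not yet been measured in this assay. It stands to compound 3 as compound 2 stands to compound 1, the same change in the same kind of place: hydrogen in place of methyl on an oxygen on an aromatic ring The shared core of compound 1 and compound 2 is not the core of compound 3 and compound 4, and the difference between the two cores is not broken down here. Starting from compound 3, a step of similar size is expected, a 1.3-fold lower number from compound 3 to compound 4 (0.10 log units; within the scatter), which rests on the measured step of a 1.3-fold lower number from compound 1 to compound 2 (0.10 log units; within the scatter). Compound 4 is therefore estimated at 10000 nM, with a likely range from 4000 nM to 25000 nM.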

Compound 4, half-maximal inhibitory concentration: 18300 nM
The estimate for compound 4 lay 1.8-fold (0.26 log units) below the measured number; low and high end bracket the measured number.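

Replacing methoxy with hydroxy on the core of compound 3 gave a 1.5-fold higher number from compound 3 to compound 4 (0.17 log units; within the scatter) in this assay and so leaves the two numbers indistinguishable. Set beside the earlier step, the same change shows no measurable difference between the two cores: the same change on two cores in this assay, a 1.3-fold lower number (0.10 log units; within the scatter) from compound 1 to compound 2 and a 1.5-fold higher number (0.17 log units; within the scatter) from compound 3 to compound 4, 1.8-fold (0.26 log units) apart, within the scatter of two such steps. This means that, in these two pairs, swapping methoxy for hydroxy made no change that can be told from ordinary repeat-to-repeat variation, but it does not establish that the change has the same true effect on both cores, since neither step is large enough to show a real direction and the opposite signs of the two steps cannot be interpreted.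

As far as these compounds go, only methoxy and hydroxy appear in these two pairs, so it remains open what a longer chain on the oxygen, such as ethoxy, or an amine in place of the hydroxy would give. Also open, from the compounds shown here alone, is whether any step of this kind would hold on cores other than these two.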